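The compounds below may be only part of what the source reports. "The series", "measured", "known", "first", "only" and "open" are said of these compounds alone.

Compound 3 `CCC(C(=O)N1CCN(c2cccc(Cl)c2)CC1)N1C(=O)CCC1=O`, compound 2 `CCC(C(=O)N1CCN(c2cccc(C(F)(F)F)c2)CC1)N1C(=O)CCC1=O` and compound 1 `CCC(C(=O)N1CCN(c2ccccc2F)CC1)N1C(=O)CCC1=O` share a core and differ only in the ring on the amine nitrogen. In a functional assay on the whole organism (strain Swiss) with Mus musculus as the target, in the maximal electroshock model, with a stated time of 0.5 h, at a dose of 100 mg/kg by the intraperitoneal route (on this read-out higher numbers stand for a stronger effect at the one dose given and lower numbers for a weaker effect), compound 3 gives 50%, compound 2 gives 50% and compound 1 gives 0%. Compound 3 thus stands level with compound 2, together the highest of the three, and well above compound 1. The step to compound 4 `CCC(C(=O)N1CCN(c2ccccc2)CC1)N1C(=O)CCC1=O` is hydrogen in place of chloro on an aromatic carbon, that is 3-chlorophenyl to phenyl. Within the data shown here, two measured steps bear on it: a number 50 percentage points higher from compound 1 to compound 3 (beyond the scatter) and no change at the digits printed from compound 2 to compound 3 (within the scatter). Neither removes a group outright, so the expected step of a number 25 percentage points lower from compound 3 to compound 4 (beyond the scatter) is uncertain, leaning towards a loss. Compound 4 is estimated at 25%, between 0% and 50%.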

Compound 4, a percentage reported as activity, at one dose (the size of the read-out at that dose, not a potency): 25%
Beside the measured number, compound 4's estimate shows no gap at the digits printed; the range from low to high includes it.
By their numbers in this assay, from the lowest: compound 1; then compound 4; then compounds 2 and 3 (each within the scatter of the next).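

Plain phenyl now gives a reference point for the ring on the amine nitrogen in this assay. Against it, the substituted rings move in opposite directions: there is a number 25 percentage points lower from compound 3 to compound 4 (beyond the scatter) and a number 25 percentage points lower from compound 2 to compound 4 (beyond the scatter) when hydrogen replaces chloro or trifluoromethyl, but a number 25 percentage points higher from compound 1 to compound 4 (beyond the scatter) when hydrogen replaces fluoro. No measurement here explains these steps.

Compound 1 differs from compound 3 in both the group and its place on the ring, so 3-fluorophenyl or 2-chlorophenyl would be needed to separate the two. From the compounds shown here alone, how a methoxy group or an amine would read on this ring also remains open.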